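Halogen swap on a benzoxazole/benzothiazole piperazine series

The source may report more compounds than this note shows. Statements on the series, on what has been measured and on what is new or still open speak of the compounds shown alone.

Compound 1 `Clc1ccc(-c2nnc(SCCCN3CCN(c4nc5ccccc5o4)CC3)o2)cc1`, compound 2 `Fc1ccc(-c2nnc(SCCCN3CCN(c4nc5ccccc5o4)CC3)o2)cc1` and compound 3 `Clc1ccc(-c2nnc(SCCCN3CCN(c4nc5ccccc5s4)CC3)o2)cc1` have been tested in a functional assay on HepG2 cells (Homo sapiens) for inhibition, read by MTT assay, with a stated time of 72 h; a higher number here means a weaker inhibitor, a lower number a stronger inhibitor. In this assay compound 1 gives 121000 nM, compound 2 gives 83800 nM and compound 3 gives 87700 nM. The change fluoro in place of chloro on an aromatic carbon produced a 1.4-fold lower number from compound 1 to compound 2 (0.16 log units; within the scatter). The change of core, (1,3-benzothiazol-2-yl in place of 1,3-benzoxazol-2-yl on an amine nitrogen in a ring), produced a 1.4-fold lower number from compound 1 to compound 3 (0.14 log units; within the scatter). All three numbers sit within the scatter of one another, so no order among them is claimed.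

Compound 4 `Fc1ccc(-c2nnc(SCCCN3CCN(c4nc5ccccc5s4)CC3)o2)cc1` remains to be measured in this assay. It differs from compound 3 by fluoro in place of chloro on an aromatic carbon, which is the same change as that from compound 1 to compound 2, at the same place, now made on the core of compound 3. For the measured compounds named here, with only one earlier instance of this change, and that one within the scatter, the expected step from compound 3 to compound 4 is small: a 1.3-fold lower number from compound 3 to compound 4 (0.10 log units; within the scatter) is estimated, resting on a 1.4-fold lower number from compound 1 to compound 2 (0.16 log units; within the scatter). Compound 4 is therefore expected to give about 70000 nM in this assay, with a likely range from 35000 nM to 140000 nM.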

Compound 4, half-maximal inhibitory concentration: 234000 nM
Compound 4: the middle estimate sits 3.3-fold (0.52 log units) below what was measured; measured number outside the range, above it.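

In this assay, 4-fluorophenyl in place of 4-chlorophenyl on the core of compound 3 gives a 2.7-fold higher number from compound 3 to compound 4 (0.43 log units; beyond the scatter), so this change does not carry over as a fixed step from the core of compound 1: the same change on two cores in this assay, a 1.4-fold lower number (0.16 log units; within the scatter) from compound 1 to compound 2 and a 2.7-fold higher number (0.43 log units; beyond the scatter) from compound 3 to compound 4, 3.9-fold (0.59 log units) apart, beyond the scatter of two such steps

Read the other way, 1,3-benzothiazol-2-yl in place of 1,3-benzoxazol-2-yl with the 4-fluorophenyl group in place gives a 2.8-fold higher number from compound 2 to compound 4 (0.45 log units; beyond the scatter), and this change also depends on its partner: the same change on two cores in this assay, a 1.4-fold lower number (0.14 log units; within the scatter) from compound 1 to compound 3 and a 2.8-fold higher number (0.45 log units; beyond the scatter) from compound 2 to compound 4, 3.9-fold (0.59 log units) apart, beyond the scatter of two such steps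

Across these four compounds, the two changes do not act independently, but a single square of compounds cannot show why they interact or whether this holds elsewhere in the series.

As far as these compounds go, it remains open whether the interaction is specific to fluoro or would also appear with another group at the same place, such as bromo or methoxy. For the compounds shown here, also open is whether it would persist with a longer chain in place of the one shared by these compounds.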